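Replacing 3-methoxyphenyl with 2-fluorophenyl in compound 2

This account rests on a few compounds, and the source may have more. Where it says the series, first, only, none or still open, it means among the compounds named here.

Measured in a functional assay on OCI-My4 cells (Homo sapiens) for antiproliferative activity, read by MTT assay, with a stated time of 72 h; on this read-out lower numbers stand for stronger inhibition and higher numbers for weaker inhibition:
Compound 1 `COc1ccc([C@H](C)NC(=O)/C(C#N)=C/c2cccc(Br)n2)cc1`: 1800 nM
Compound 2 `COc1cccc([C@H](C)NC(=O)/C(C#N)=C/c2cccc(Br)n2)c1`: 3100 nM
Compound 3 `C[C@H](NC(=O)/C(C#N)=C/c1cccc(Br)n1)c1cccc(C(F)(F)F)c1`: 1800 nM

Compound 2, at 3100 nM, stands within the scatter of both other compounds. Compound 4 `C[C@H](NC(=O)/C(C#N)=C/c1cccc(Br)n1)c1ccccc1F` has not yet been measured. It shares the core of compound 2 and differs in one group: 2-fluorophenyl in place of 3-methoxyphenyl on a saturated chain carbon bound to an amide-type nitrogen and a saturated chain carbon. In words, 2-fluorophenyl sits in place of 3-methoxyphenyl on a saturated chain carbon bound to an amide-type nitrogen and a saturated chain carbon.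

For the measured compounds named here, two measured steps bear on this change. Putting 3-methoxyphenyl in place of 4-methoxyphenyl gave a 1.7-fold higher number from compound 1 to compound 2 (0.24 log units; within the scatter). Putting trifluoromethyl in place of methoxy gave a 1.7-fold lower number from compound 2 to compound 3 (0.24 log units; within the scatter). Neither step goes beyond the scatter, although none of the three compounds carries 2-fluorophenyl, so this is only indirect guidance. From the compounds shown here alone, no change beyond the scatter is expected in this assay, and the direction remains open. The expected size is a 1.3-fold lower number from compound 2 to compound 4 (0.13 log units; within the scatter). Compound 4 is estimated at 2300 nM, with an expected range of 1000 nM to 5000 nM.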

Compound 4, half-maximal inhibitory concentration: 2400 nM
Compound 4: the middle estimate sits 1.0-fold (0.02 log units) below what was measured; low and high end bracket the measured number.
By their numbers in this assay, from the lowest: compounds 1, 3, 4 and 2 (each within the scatter of the next).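

In this assay the swap to 2-fluorophenyl gave a 1.3-fold lower number from compound 2 to compound 4 (0.11 log units; within the scatter) and, measured against the 4-methoxyphenyl group, a 1.3-fold higher number from compound 1 to compound 4 (0.12 log units; within the scatter) on the same shared core. This position, on a saturated chain carbon bound to an amide-type nitrogen and a saturated chain carbon, has now carried a phenyl ring with a single fluorine and neither methoxy nor trifluoromethyl, with no step beyond the scatter. The entering group also has one heavy atom fewer and no hydrogen-bond acceptor, yet that difference in count comes with no change that the scatter can separate. No supporting measurement bears on this result.

Still open, from the compounds shown here alone, is whether 3-fluorophenyl or 4-fluorophenyl would match 2-fluorophenyl here. An amine or a carboxylic acid on this phenyl ring might also give a step beyond the scatter.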